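Clearance after replacing 1-acetylpiperidin-4-yl with a substituted pyrazole

The compounds below may be only part of what the source reports. "The series", "measured", "known", "first", "only" and "open" are said of these compounds alone.

Measured so far in an ADME assay on microsomes from liver (Homo sapiens) for metabolic stability, read by LC-MS, using NADPH, with stated times of 5 min and 30 min, tested at 1 uM; on this read-out lower numbers stand for slow clearance and higher numbers for fast clearance
- compound 1 `Cn1cc(-c2cnc(NCc3c(F)ccc4c3CCO4)c3cn[nH]c(=O)c23)cn1` gives 21 mL.min-1.g-1
- compound 2 `CC(=O)N1CCC(c2cnc(NCc3c(F)ccc4c3CCO4)c3cn[nH]c(=O)c23)CC1` gives 207 mL.min-1.g-1

Compound 2 stands highest of the two measured compounds at 207 mL.min-1.g-1 in this assay, and compound 1 is its nearest neighbour. The next compound to be measured is compound 3 `CN(C)C(=O)c1cc(-c2cnc(NCc3c(F)ccc4c3CCO4)c3cn[nH]c(=O)c23)n(C)n1`, with 3-(dimethylcarbamoyl)-1-methyl-1H-pyrazol-5-yl in place of 1-acetylpiperidin-4-yl on an aromatic carbon. Going by the values given here, one measured step bears on this change: a 9.9-fold higher number from compound 1 to compound 2 (0.99 log units; beyond the scatter), beyond the scatter, with 1-acetylpiperidin-4-yl in place of 1-methyl-1H-pyrazol-4-yl on an aromatic carbon. Compound 3 again has a five-membered aromatic ring at this carbon, as does compound 1 (21 mL.min-1.g-1), so a partial return towards that value is expected. Among the compounds with values here, the extra dimethylcarbamoyl group has no measured counterpart, and this single step is thin support. The expected change is a 4.6-fold lower number from compound 2 to compound 3 (0.66 log units; beyond the scatter), a lower number and beyond the scatter. The estimated value for compound 3 is 45 mL.min-1.g-1 (15 mL.min-1.g-1 to 130 mL.min-1.g-1).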

Compound 3, intrinsic clearance in microsomes: 21 mL.min-1.g-1
Estimate against measurement, compound 3: 2.1-fold (0.33 log units) above, and the stated range covers the measured number.
By their numbers in this assay, from the lowest: compounds 1 and 3 (each within the scatter of the next); then compound 2.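

In this assay, 3-(dimethylcarbamoyl)-1-methyl-1H-pyrazol-5-yl in place of 1-acetylpiperidin-4-yl on this aromatic carbon gives a 9.9-fold lower number from compound 2 to compound 3 (0.99 log units; beyond the scatter), a step of the same size as the earlier one between compound 1 and compound 2 but in the opposite direction. The two pyrazoles show no change at the digits printed from compound 1 to compound 3 (within the scatter), so the added dimethylcarbamoyl group and the different point of attachment of the pyrazole together leave the number where it stood, and among these three compounds the high clearance number belongs to compound 2 alone. No measurement available here accounts for the two pyrazoles standing together or for compound 2 standing apart.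

On these data alone, whether the high number of compound 2 goes with its non-aromatic ring or with its acetyl group stays open, and a free piperidine amine or a tetrahydropyran at this carbon would separate the two. Also open, as far as these compounds go, is how much the pyrazole tolerates at the place of the dimethylcarbamoyl group, for example a carboxylic acid or a longer chain.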